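The compounds below may be only part of what the source reports. "The series", "measured", "known", "first", "only" and "open" are said of these compounds alone.

Measured compounds:
compound 1 `C=C1C[C@](CBr)(c2ccccc2)OC1=O`: 1330 nM
compound 2 `C=C1C[C@](CCl)(c2ccccc2)OC1=O`: 30600 nM
compound 3 `C=C1CC(c2ccccc2)(C(Br)c2ccccc2)OC1=O`: 4190 nM

Values are from a functional assay on A-431 cells (Homo sapiens) for antiproliferative activity, read by sulforhodamine B assay, with a stated time of 72 h (on this read-out lower numbers stand for stronger inhibition and higher numbers for weaker inhibition), on all three. The step of a 23-fold higher number from compound 1 to compound 2 (1.36 log units; beyond the scatter) is the change (chloro in place of bromo on a saturated chain carbon bound to a saturated ring carbon). Compound 4 `C=C1CC(c2ccccc2)(C(Cl)c2ccccc2)OC1=O` is not yet measured; it differs from compound 3 by chloro in place of bromo on a saturated chain carbon bound to an aromatic carbon and a saturated ring carbon. The difference between the core of compound 1 and the core of compound 3 is not broken down here. The two exchanges are the same kind of change, not the same: in compound 1 the place is a saturated chain carbon bound to a saturated ring carbon, while in compound 3 the place is a saturated chain carbon bound to an aromatic carbon and a saturated ring carbon. Going by the values given here, with only one pair measured for this exchange, the expectation for a 9.5-fold higher number from compound 3 to compound 4 (0.98 log units; beyond the scatter) rests on a 23-fold higher number from compound 1 to compound 2 (1.36 log units; beyond the scatter) alone, and the different surroundings of the place leave room for a smaller or larger step. Compound 4 is estimated at 40000 nM in this assay, within 10000 nM to 150000 nM.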

Compound 4, half-maximal inhibitory concentration: 2770 nM
The estimate for compound 4 lay 14-fold (1.16 log units) above the measured number; measured number outside the range, below it.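

In this assay, the exchange of bromo for chloro gives a 1.5-fold lower number from compound 3 to compound 4 (0.18 log units; within the scatter), so bromo and chloro cannot be told apart on this core, whereas the same exchange gave a 23-fold higher number from compound 1 to compound 2 (1.36 log units; beyond the scatter) on the core of compound 1. Set side by side, the two steps differ, and the large step does not carry over from one core to the other: the same change on two cores in this assay, a 23-fold higher number (1.36 log units; beyond the scatter) from compound 1 to compound 2 and a 1.5-fold lower number (0.18 log units; within the scatter) from compound 3 to compound 4, 35-fold (1.54 log units) apart, beyond the scatter of two such steps This does not show which feature of the cores sets the size of the step, nor what a third core would give; the place itself also differs, being a saturated chain carbon bound to a saturated ring carbon in compound 1 and a saturated chain carbon bound to an aromatic carbon and a saturated ring carbon in compound 3.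

The compounds shown leave open how an amine or a hydroxyl group at this place would compare with bromo and chloro. They also leave open whether substituents such as methoxy on the phenyl rings would alter either step.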